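A new amino substituent on compound 2

The compounds below may be only part of what the source reports. "The series", "measured", "known", "first", "only" and "open" are said of these compounds alone.

- Compound 1 `CC1=CCC[C@H]2[C@](C)(CC3=CC(=O)C(N4CCC[C@H]4C(=O)O)=CC3=O)[C@@H](C)CC[C@]12C`: 35400 nM
- Compound 2 `CC1=CCC[C@H]2[C@](C)(CC3=CC(=O)C=CC3=O)[C@@H](C)CC[C@]12C`: 17100 nM
- Compound 3 `CC(C)(C)C1=CC(=O)C=CC1=O`: 15500 nM

All three compounds were measured in a functional assay on K562 cells (Homo sapiens) for cytotoxicity, read by MTT assay, with a stated time of 72 h; a higher number here means a weaker inhibitor, a lower number a stronger inhibitor. Compound 2, at 17100 nM, stands level with compound 3 within the scatter, while compound 1 reads higher, beyond the scatter.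

Compound 4 `CC1=CCC[C@H]2[C@](C)(CC3=CC(=O)C=C(N[C@@H](C(=O)O)C(C)C)C3=O)[C@@H](C)CC[C@]12C` has (1-carboxy-2-methylpropyl)amino in place of hydrogen on a double-bonded ring carbon of compound 2: (1-carboxy-2-methylpropyl)amino in place of hydrogen on a double-bonded ring carbon.

For the measured compounds named here, only one measured step bears on this change. Replacing 2-carboxypyrrolidin-1-yl with hydrogen gave a 2.1-fold lower number from compound 1 to compound 2 (0.32 log units; beyond the scatter), a modest step. It is a related replacement, not the same one, so it offers only a rough guide. Read in reverse, it suggests that adding the new group should raise the number modestly in this assay.

The expected step is a 1.8-fold higher number from compound 2 to compound 4 (0.24 log units; within the scatter). Compound 4 is estimated at 30000 nM, with an expected range of 13000 nM to 70000 nM.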

Compound 4, half-maximal inhibitory concentration: 7780 nM
Compound 4: middle estimate off by 3.9-fold (0.59 log units), on the high side, outside the stated range (below it).
By their numbers in this assay, from the lowest: compounds 4, 3 and 2 (each within the scatter of the next, the first and the last beyond it); then compound 1.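

In this assay, (1-carboxy-2-methylpropyl)amino in place of hydrogen on a double-bonded ring carbon, two ring bonds from the ring atom that bears a large group, gave a 2.2-fold lower number from compound 2 to compound 4 (0.34 log units; beyond the scatter). This shows that a substituent carrying both an amino nitrogen and a carboxylic acid need not raise the number, although the earlier step, a 2.1-fold lower number from compound 1 to compound 2 (0.32 log units; beyond the scatter), had pointed that way for 2-carboxypyrrolidin-1-yl. No measurement shown here accounts for the opposite directions of these two steps.

The compounds shown leave open whether the carboxylic acid, the amino nitrogen or the branched isopropyl side chain drives the change at this position. A plain amino group, a methyl ester in place of the carboxylic acid, or a longer unbranched chain would each separate those parts.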